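From Compound 3 to Compound 4: Swapping the Amide Substituent

The source may report more compounds than this note shows. Statements on the series, on what has been measured and on what is new or still open speak of the compounds shown alone.

Values from a functional assay on HeLa cells (Homo sapiens) for cytotoxicity, read by MTT assay, with a stated time of 48 h (on this read-out higher numbers stand for weaker inhibition and lower numbers for stronger inhibition), for the three measured compounds:
compound 1 `CC[C@H](C)[C@H](NC(=O)CSC1=C(OC)C(=O)c2ccccc2C1=O)C(=O)OC` gives 82000 nM
compound 2 `COC(=O)[C@H](CC(C)C)NC(=O)CSC1=C(OC)C(=O)c2ccccc2C1=O` gives 63000 nM
compound 3 `COC(=O)[C@@H](NC(=O)CSC1=C(OC)C(=O)c2ccccc2C1=O)C(C)C` gives 93500 nM

Compound 3, at 93500 nM in this assay, cannot be separated from the other two compounds. The steps that reach it are a 1.1-fold higher number from compound 1 to compound 3 (0.06 log units; within the scatter) and a 1.5-fold higher number from compound 2 to compound 3 (0.17 log units; within the scatter), so its value stands level with theirs within the scatter.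

Compound 4 `COC(=O)CCCNC(=O)CSC1=C(OC)C(=O)c2ccccc2C1=O` has not been measured. It carries 3-(methoxycarbonyl)propyl in place of 1-(methoxycarbonyl)-2-methylpropyl on an amide-type nitrogen, and the exchange counts out as 3-(methoxycarbonyl)propyl in place of 1-(methoxycarbonyl)-2-methylpropyl on an amide-type nitrogen for the whole swap.

The nearest evidence comes from the changes of this side group among the measured compounds. Alongside the two steps above stands a 1.3-fold lower number from compound 1 to compound 2 (0.11 log units; within the scatter), and none of the three leaves the scatter. None of them brings in 3-(methoxycarbonyl)propyl, however, so the new group has no direct test yet. Going by those three small steps, no change beyond the scatter is expected in this assay in either direction. The estimated step is a 1.2-fold lower number from compound 3 to compound 4 (0.10 log units; within the scatter) and it remains an expectation until measured. For compound 4 the estimated value is 75000 nM with an expected range of 35000 nM to 150000 nM in repeated measurements.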

Compound 4, half-maximal inhibitory concentration: 24000 nM
The estimate for compound 4 lay 3.1-fold (0.49 log units) above the measured number, outside the stated range (below it).
By their numbers in this assay, from the lowest: compound 4; then compounds 2, 1 and 3 (each within the scatter of the next).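

The side group on the amide-type nitrogen turns out to matter in this assay: exchanges among the three earlier groups all stayed within the scatter, whereas 3-(methoxycarbonyl)propyl moves the number beyond it in all three comparisons (a 3.9-fold lower number from compound 3 to compound 4 (0.59 log units; beyond the scatter); a 2.6-fold lower number from compound 2 to compound 4 (0.42 log units; beyond the scatter); a 3.4-fold lower number from compound 1 to compound 4 (0.53 log units; beyond the scatter)). The steps are modest, but compound 4 is the only one of the four set apart from the rest, and its lower number stands for stronger inhibition. Its group differs from the 1-(methoxycarbonyl)-2-methylpropyl of compound 3 in several ways at once, with one heavy atom fewer, no defined stereocentre and a different name-position for the methoxycarbonyl, and no measurement available here explains the gain.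

Among the compounds shown here, with only one group of the new kind, these compounds cannot show which of those differences carries the step. They also leave open what a longer chain, or a carboxylic acid or an amine in place of the methoxycarbonyl, would do to the number on this chain.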